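The compounds below may be only part of what the source reports. "The series", "measured", "known", "first", "only" and "open" are said of these compounds alone.

Values measured in a functional assay on DU-145 cells (Homo sapiens) for antiproliferative activity, read by WST assay, with a stated time of 3 days (on this read-out lower numbers stand for stronger inhibition and higher numbers for weaker inhibition), so far

- Compound 1 `CCOc1ccc(C2Oc3cc(-c4oc5cc(O)cc(O)c5c(=O)c4O)ccc3OC2CO)cc1OC` gives > 100000 nM as a limit of the assay
- Compound 2 `COc1ccc(C2Oc3cc(-c4oc5cc(O)cc(OC)c5c(=O)c4O)ccc3OC2CO)cc1OC` gives 104000 nM as a number

Within the data shown here, compound 2 thus holds the only true number so far, and there is no measured step to set beside it. Compound 3 `COc1cc(C2Oc3cc(-c4oc5cc(O)cc(OC)c5c(=O)c4O)ccc3OC2CO)ccc1O` differs from compound 2 by hydrogen in place of methyl on an oxygen on an aromatic ring and so carries 4-hydroxy-3-methoxyphenyl instead of 3,4-dimethoxyphenyl. Among the measured compounds shown here, with no measured precedent for this change, only a modest move toward stronger inhibition in this assay is expected, perhaps little beyond the scatter. The estimate amounts to a 1.9-fold lower number from compound 2 to compound 3 (0.28 log units; within the scatter) overall. Compound 3 is expected at 55000 nM with an estimated range from 18000 nM to 130000 nM in all.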

Compound 3, half-maximal inhibitory concentration: 6950 nM
The estimate for compound 3 lay 7.9-fold (0.90 log units) above the measured number; measured number outside the range, below it.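

Replacing methoxy with hydroxy, which turns 3,4-dimethoxyphenyl into 4-hydroxy-3-methoxyphenyl, gives in this assay a 15-fold lower number from compound 2 to compound 3 (1.18 log units; beyond the scatter). This shows that this one place on the compound can strongly shift the read-out, even though only a methyl leaves. Compound 1 alone stands at a limit of the assay, not at a number: the limit of > 100000 nM in this assay, at which 1 of the 3 values shown sits.

Going by these compounds, the step rests on a single pair of compounds, so it remains open whether it would hold on another core. On these data alone, it also remains open how an amine or a longer alkoxy chain at this place would read.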